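The source may report more compounds than this note shows. Statements on the series, on what has been measured and on what is new or still open speak of the compounds shown alone.

Working notes on the oxazolyl ketone series. For the measured compounds named here, compound 1 `O=C(CCCC1CCN(C(=O)C2CCCCC2)CC1)c1ncco1` gives 45 nM in an assay on isolated protein for inhibition of Fatty-acid amide hydrolase 1 (Homo sapiens); a lower number here means a stronger inhibitor, a higher number a weaker inhibitor; it stands second highest of the three numbers measured so far. Compound 3 `CC(C)(C)CC(=O)N1CCC(CCCC(=O)c2ncco2)CC1` gives 90 nM, and the change of neopentyl in place of cyclohexyl on a carbonyl carbon gives a 2.0-fold higher number from compound 1 to compound 3 (0.30 log units; within the scatter). Going by the values given here, compound 2 `O=C(CCCC1CCN(S(=O)(=O)CCc2ccccc2)CC1)c1ncco1` gives 6 nM, the lowest number of the three; no single-place step to compound 2 is tabulated, so its value is noted only as what it shows.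

Compound 4 `O=C(CCCC1CCN(Cc2ccccc2Br)CC1)c1ncco1` differs from compound 1 by 2-bromobenzyl in place of cyclohexylcarbonyl on an amine nitrogen in a ring. Among the compounds with values here, no measured step bears on this exchange: the one tabulated step keeps the carbonyl on the ring nitrogen and alters only the group beyond it, whereas here the cyclohexylcarbonyl leaves as a whole and 2-bromobenzyl enters in its place. With nothing comparable measured, the expectation for compound 4 is set loosely and widened; a step of a 6.7-fold higher number from compound 1 to compound 4 (0.82 log units; beyond the scatter) is expected, toward a higher number. Compound 4 is therefore estimated at 300 nM, with a range of 60 nM to 1500 nM.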

Compound 4, half-maximal inhibitory concentration: 315 nM
Beside the measured number, compound 4's estimate is 1.1-fold (0.02 log units) below it; low and high end bracket the measured number.
By their numbers in this assay, from the lowest: compound 2; then compounds 1 and 3 (each within the scatter of the next); then compound 4.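

In this assay, exchanging the whole group on the amine nitrogen in the ring gives steps beyond the scatter, a 7.0-fold higher number from compound 1 to compound 4 (0.85 log units; beyond the scatter) and a 3.5-fold higher number from compound 3 to compound 4 (0.54 log units; beyond the scatter), whereas the earlier change beyond the carbonyl stayed within it. The change at this position therefore does more than the neopentyl for cyclohexyl exchange, although the entering and leaving groups match in heavy-atom count and differ in the carbonyl, the hydrogen-bond acceptor, the aromatic ring and the bromine. Nothing at hand explains the higher number of compound 4.

The compounds shown do not separate the loss of the carbonyl from the arrival of the 2-bromobenzyl group. An unsubstituted benzyl or a 2-bromobenzoyl group on the same nitrogen would bear directly on that question.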